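The source may hold more compounds than are shown below. What is called first, only, known or untested is meant among the compounds shown, and "the series" means these compounds.

Within the data shown here, in a functional assay on C8166 cells (Homo sapiens) for cytotoxicity, read by MTT assay, with a stated time of 72 h (a higher number here means that more compound is tolerated, a lower number that less compound is tolerated), each of the three compounds measured so far has only a limit and no actual number. Compound 1 `C/C(=N\NC(=O)Cn1c(=O)c(C)nc2ccccc21)c1ccccc1Cl` gives a limit of > 543000 nM. Compound 2 `Cc1ccc(S(=O)(=O)N2CC3(C[C@H]2C(=O)NN)SCCS3)cc1` gives a limit of > 519000 nM. Compound 3 `COc1ccc(/C=C/C(=O)N2C[C@@H](NC(=O)c3cccnc3)C[C@H]2C(=O)NO)cc1OC` gives a limit of > 454000 nM. Compound 2 therefore stands with the other two, with a limit as its only result.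

Compound 4 `Cc1ccc(S(=O)(=O)N2CC3(C[C@H]2C(=O)N/N=C/c2cccc([N+](=O)[O-])c2)SCCS3)cc1` differs from compound 2 on an amide-type nitrogen: a group of 11 heavy atoms (7 carbon, 2 nitrogen, 2 oxygen; one six-membered aromatic ring of carbon only) in place of one nitrogen atom, on an amide-type nitrogen. Among the measured compounds shown here, no measured pair shows what such a change does, so any step size is a judgement. A moderate move toward less compound being tolerated is expected, and another limit is quite possible. The expected change is an at least 2.0-fold lower number from compound 2 to compound 4 (0.31 log units; beyond the scatter). For compound 4, the estimated value is 250000 nM, with an expected range of 60000 nM to 420000 nM.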

Compound 4, half-maximal cytotoxic concentration: > 395000 nM
Compound 4: only a limit was reported (the forecaster's own chance of this, stated with the estimate: 65%); middle value at least 1.5-fold (0.19 log units) away from the limit.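

Compound 2 and compound 4 each carry only a limit in this assay, so the step between them cannot be read. The compounds shown leave open what concentration of any of them actually harms these cells.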